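Heteroaryl swap at the sulfonamide nitrogen of compound 3

The compounds below may be only part of what the source reports. "The series", "measured", "known", "first", "only" and "open" are said of these compounds alone.

Three members of the series have numbers in a functional assay on MCF7 cells (Homo sapiens) for cytotoxicity, read by CCK-8 assay, with a stated time of 48 h; on this read-out lower numbers stand for stronger inhibition and higher numbers for weaker inhibition. Compound 1 `O=c1oc2ccccc2c(Cl)c1/C=N/c1ccc(S(=O)(=O)Nc2nccs2)cc1` gives 160 nM in this assay. Compound 2 `Cc1cc(C)nc(NS(=O)(=O)c2ccc(/N=C/c3c(Cl)c4ccccc4oc3=O)cc2)n1` gives 20 nM. Compound 3 `Cc1ccc2oc(=O)c(/C=N/c3ccc(S(=O)(=O)Nc4nccs4)cc3)c(Cl)c2c1` gives 33 nM; its gap to compound 2 lies within the scatter, while its separation from compound 1 is a 4.8-fold lower number from compound 1 to compound 3 (0.69 log units; beyond the scatter), beyond the scatter. Compound 4 `Cc1ccc2oc(=O)c(/C=N/c3ccc(S(=O)(=O)Nc4nccc(C)n4)cc3)c(Cl)c2c1` has no number yet; it differs from compound 3 by 4-methylpyrimidin-2-yl in place of 1,3-thiazol-2-yl on a sulfonamide nitrogen. Among the compounds with values here, one measured step bears on this change: an 8.0-fold lower number from compound 1 to compound 2 (0.90 log units; beyond the scatter), where 4,6-dimethylpyrimidin-2-yl replaced 1,3-thiazol-2-yl on the same sulfonamide nitrogen. The entering ring of compound 4 carries a single methyl rather than two, so a step in the same direction is expected, though it may fall somewhat short of that earlier step. On this basis compound 4 is expected to give 8 nM, within a range from 3 nM to 25 nM. The expected step is therefore a 4.1-fold lower number from compound 3 to compound 4 (0.62 log units; beyond the scatter), toward a lower number.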

Compound 4, half-maximal inhibitory concentration: 61 nM
Compound 4: the middle estimate sits 7.6-fold (0.88 log units) below what was measured; the whole stated range lies below it.
By their numbers in this assay, from the lowest: compounds 2, 3 and 4 (each within the scatter of the next, the first and the last beyond it); then compound 1.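

In this assay the swap at the sulfonamide nitrogen, made on the methyl-bearing core, gives a 1.8-fold higher number from compound 3 to compound 4 (0.27 log units; within the scatter) and so does not separate the 4-methylpyrimidin-2-yl ring from the 1,3-thiazol-2-yl ring on this core. The earlier step of an 8.0-fold lower number from compound 1 to compound 2 (0.90 log units; beyond the scatter) therefore does not carry over as a general effect of replacing the 1,3-thiazol-2-yl ring at this position; that step differs in the entering ring, with its second methyl, and in a core without the methyl. No measured evidence bears on this result, so the contrast between the two steps stays unexplained.

The compounds shown leave open whether the second methyl on the entering ring or the methyl on the core governs the contrast; 4,6-dimethylpyrimidin-2-yl on the core of compound 3 would address this. Also open, as far as these compounds go, is how a pyridin-2-yl ring or an acetyl group would read on the same nitrogen.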